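A few compounds are considered here, and "the series" means these few. Any claim that something is new, unique, unknown or untested is made for them only; others in the source may bear on it.

Compound 3 `N#CC1=C(N)Oc2c(N)cc3nc4ccccc4nc3c2C12C(=O)N(Cc1cnnn1-c1ccccc1Br)c1ccccc12` is the only one of the three measured compounds for which a functional assay on A549 cells (Homo sapiens) for antiproliferative activity, read by MTT assay, with a stated time of 48 h (on this read-out higher numbers stand for weaker inhibition and lower numbers for stronger inhibition), returns a number: in this assay compound 3 gives 27400 nM. Compound 1 `N#CC1=C(N)Oc2c(c3nc4ccccc4nc3c3ccccc23)C12C(=O)N(Cc1cnnn1-c1ccc(S(N)(=O)=O)cc1)c1ccccc12` reaches only a limit of the assay, > 50000 nM. Compound 2 `Cc1ccc(-n2nncc2CN2C(=O)C3(C(C#N)=C(N)Oc4c3c3nc5ccccc5nc3c3ccccc43)c3ccccc32)cc1C` likewise reaches only a limit of the assay, > 50000 nM. For the measured compounds named here, the one change that joins compounds 1 and 2, a step that the two limits leave unreadable from compound 1 to compound 2, is therefore unreadable, and compound 3 stands alone as the sole numeric result, the other two values sitting at the limit of > 50000 nM in this assay, at which 2 of the 3 values shown sit. Compound 4 `N#CC1=C(N)Oc2c(N)cc3nc4ccccc4nc3c2C12C(=O)N(Cc1cnnn1-c1ccc(Cl)cc1Cl)c1ccccc12` differs from compound 3 in one place: 2,4-dichlorophenyl in place of 2-bromophenyl on an aromatic nitrogen. Going by the values given here, the only other change at this aromatic nitrogen, between compound 1 and compound 2, ends at the limit on both sides, so no measured step gives a size for swapping one aryl group for another there. No step beyond the scatter is therefore expected from compound 3 to compound 4, a 1.1-fold higher number from compound 3 to compound 4 (0.04 log units; within the scatter). Compound 4 is estimated at 30000 nM in this assay, with a range from 10000 nM to 100000 nM.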

Compound 4, half-maximal inhibitory concentration: > 50000 nM
Compound 4 gave a limit, no number; the forecaster's own chance of this, stated with the estimate: 40%; middle value at least 1.6-fold (0.22 log units) from the limit.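

Unlike the step between compound 1 and compound 2, where both sides sit at a limit, this change at the aromatic nitrogen has a number on one side, which gives the step a floor: in this assay the change reads as an at least 1.8-fold higher number from compound 3 to compound 4 (0.26 log units; that floor lies within the scatter). On these data alone, the value of compound 4 is a limit and not a number, so the true size of this step stays unknown, and the floor alone does not separate 2,4-dichlorophenyl from 2-bromophenyl. Compound 3 remains the only compound with a number in this assay, and the other values give no second point of comparison: the limit of > 50000 nM in this assay, at which 3 of the 4 values shown sit.

As far as these compounds go, it stays open whether a plain phenyl or a pyridine ring on this aromatic nitrogen would give a number at all. Also open, from the compounds shown here alone, is how far such a number would lie from that of compound 3.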